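Spiro amine replaces fused bicyclic amine on the shared core

The compounds below may be only part of what the source reports. "The series", "measured", "known", "first", "only" and "open" are said of these compounds alone.

Measured compounds:
compound 1, `O=C(OC(C(F)(F)F)C(F)(F)F)N1CCN(Cc2ccc(C(F)(F)F)cc2N2C[C@H]3CC[C@@H](C2)O3)CC1`, 14 nM
compound 2, `O=C(OC(C(F)(F)F)C(F)(F)F)N1CCN(Cc2ccc(C(F)(F)F)cc2N2[C@@H]3CC[C@H]2COC3)CC1`, 48 nM
compound 3, `O=C(OC(C(F)(F)F)C(F)(F)F)N1CCN(Cc2ccc(C(F)(F)F)cc2N2CC3COCC3C2)CC1`, 17 nM

All three compounds were tested in an assay on brain for inhibition of Monoglyceride lipase (Mus musculus), with a stated time of 30 min; on this read-out lower numbers stand for stronger inhibition and higher numbers for weaker inhibition. Compound 3 stands alongside compound 1, the two being within the scatter of one another, as the step of a 1.2-fold higher number from compound 1 to compound 3 (0.08 log units; within the scatter) shows. Against compound 2 the gap is real: the step of a 2.8-fold lower number from compound 2 to compound 3 (0.45 log units; beyond the scatter) puts compound 3 clearly at the stronger end. The whole spread across the three bicyclic amines is modest, bounded by the step of a 3.4-fold higher number from compound 1 to compound 2 (0.54 log units; beyond the scatter).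

Compound 4, `O=C(OC(C(F)(F)F)C(F)(F)F)N1CCN(Cc2ccc(C(F)(F)F)cc2N2CCC3(CCOCC3)C2)CC1`, differs from compound 3 in that (a group of 10 heavy atoms (8 carbon, 1 nitrogen, 1 oxygen; one five-membered non-aromatic ring with 1 hetero atom, one six-membered non-aromatic ring with 1 hetero atom) in place of a group of 8 heavy atoms (6 carbon, 1 nitrogen, 1 oxygen; 2 five-membered non-aromatic rings with 1 hetero atom each), on an aromatic carbon). The new group sits on an aromatic carbon of a six-membered aromatic ring of carbon only, ortho to a large group and meta to a trifluoromethyl group. Going by the values given here, no measured step exchanges a fused bicyclic amine for a spiro one, so the bearing of the earlier steps is indirect: they only show that changing the shape of this amine moves this assay by small to modest amounts. A step of similar size, most likely toward a higher number, is therefore expected: a 1.8-fold higher number from compound 3 to compound 4 (0.25 log units; within the scatter). Compound 4 is estimated at 30 nM, with a range from 10 nM to 100 nM.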

Compound 4, half-maximal inhibitory concentration: 24 nM
The estimate for compound 4 lay 1.3-fold (0.10 log units) above the measured number; the measured number falls inside the stated range.
By their numbers in this assay, from the lowest: compounds 1, 3, 4 and 2 (each within the scatter of the next, the first and the last beyond it).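

In this assay, going by these compounds alone, all earlier amines had 8 heavy atoms, so compound 4 is the first test of a group of 10 heavy atoms on this aromatic carbon, and of a spiro link between one five-membered and one six-membered ring. The added size does not separate it from any earlier compound, as all three steps lie within the scatter (a 1.4-fold higher number from compound 3 to compound 4 (0.15 log units; within the scatter); a 1.7-fold higher number from compound 1 to compound 4 (0.23 log units; within the scatter); a 2.0-fold lower number from compound 2 to compound 4 (0.30 log units; within the scatter)), even though compounds 1 and 2 lie beyond the scatter of each other. The position therefore accepts this spiro amine among the bicyclic amines shown, although no evidence on hand explains the result.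

Every amine shown keeps one ring oxygen, so the role of that oxygen remains open, and an all-carbon spiro amine would address it. On these data alone, whether the position needs a bicyclic amine at all also remains open, a question that a single-ring amine such as morpholine or piperidine would answer.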